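Working notes: fluoro step from compound 1 to compound 3

The source may hold more compounds than are shown below. What is called first, only, known or untested is meant among the compounds shown, and "the series" means these compounds.

compound 1 `N/C(=N\NC(=S)N1CCCCCC1)c1ccccn1`: 77.5%
compound 2 `Cc1cccc(/C(N)=N/NC(=S)N2CCCCCC2)n1`: 76.7%

In a functional assay on A-431 cells (Homo sapiens) for cytotoxicity, read by MTT assay, with a stated time of 72 h, tested at 100 uM (on this read-out higher numbers stand for more inhibition of growth at the one concentration tested and lower numbers for less inhibition of growth), compound 1 gives 77.5%, the highest of the two numbers; compound 2 gives 76.7%, and the step of a number 0.8 percentage points lower from compound 1 to compound 2 (within the scatter) lies within the scatter. Compound 3 `N/C(=N\NC(=S)N1CCCCCC1)c1ccc(F)cn1` differs from compound 1 by fluoro in place of hydrogen on an aromatic carbon, two atoms from the ring nitrogen, para to a large group. Among the measured compounds shown here, the one measured step concerns another group at another carbon and bears only loosely on this change; it produced nothing beyond the scatter. The step of a number 2.5 percentage points lower from compound 1 to compound 3 (within the scatter) is therefore expected to stay within the scatter. For compound 3 the estimate is 75%, within 60% to 88%.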

Compound 3, percent growth inhibition at one concentration: 83.5%
Compound 3: middle estimate off by 8.5 percentage points, on the low side, within the range that was stated.
By their numbers in this assay, from the lowest: compounds 2, 1 and 3 (each within the scatter of the next).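

In this assay fluoro in place of hydrogen on this aromatic carbon, two atoms from the ring nitrogen and para to a large group, gives a number 6 percentage points higher from compound 1 to compound 3 (within the scatter), so this position accepts a fluoro group without a change beyond the scatter. The earlier methyl step concerned another carbon and showed nothing about this one. No measurement bears on why the result came out this way. As far as these compounds go, whether an amine, a carboxylic acid or a longer chain on this same carbon would keep the growth inhibition remains open.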